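This account rests on a few compounds, and the source may have more. Where it says the series, first, only, none or still open, it means among the compounds named here.

Across the shared core the aryl group on the ring amine nitrogen is varied. In a functional assay on HL-60 cells (Homo sapiens) for inhibition, read by MTT assay, with a stated time of 72 h (on this read-out lower numbers stand for stronger inhibition and higher numbers for weaker inhibition), compound 1 `Cc1nc(-c2ccccc2)c(C(=O)N2CCN(c3cccc(C#N)c3)CC2)o1` gives 39.6 nM and compound 3 `Cc1nc(-c2ccccc2)c(C(=O)N2CCN(c3ccc(C)c(C)c3)CC2)o1` gives 43 nM. Compound 2 `C=C(C)c1ccc(N2CCN(C(=O)c3oc(C)nc3-c3ccccc3)CC2)cc1` is reported as "not active" (no number reported) in this assay. Compound 3 thus holds the higher of the two numbers, its nearest neighbour being compound 1, with a 1.1-fold higher number from compound 1 to compound 3 (0.04 log units; within the scatter). Compound 4 `CC(=O)Nc1cccc(N2CCN(C(=O)c3oc(C)nc3-c3ccccc3)CC2)c1` differs from compound 3 by 3-acetamidophenyl in place of 3,4-dimethylphenyl on an amine nitrogen in a ring. Among the measured compounds shown here, no measured step introduces an acetamido group at this position; the one step there, a 1.1-fold higher number from compound 1 to compound 3 (0.04 log units; within the scatter), stayed within the scatter, while compound 2 shows a group at the same place can abolish activity. In this assay compound 4 is expected near 60 nM, ranging from 20 nM to 250 nM. This estimate implies a 1.4-fold higher number from compound 3 to compound 4 (0.14 log units; within the scatter).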

Compound 4, half-maximal inhibitory concentration: 329 nM
Estimate against measurement, compound 4: 5.5-fold (0.74 log units) below; measured number above the stated range.
By their numbers in this assay, from the lowest: compounds 1 and 3 (each within the scatter of the next); then compound 4.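

In this assay the aryl group on the ring amine nitrogen tolerates a change of group only in part: 3-acetamidophenyl in place of 3,4-dimethylphenyl gives a 7.7-fold higher number from compound 3 to compound 4 (0.88 log units; beyond the scatter) and acetamido in place of cyano gives an 8.3-fold higher number from compound 1 to compound 4 (0.92 log units; beyond the scatter) on the same ring. Compound 4 therefore shows an intermediate outcome at this position, a clear loss that still leaves a number, unlike the "not active" compound 2. No data on the origin of this loss are at hand.

On these data alone, whether an amine or a carboxylic acid in place of the acetamido group would also retain a number stays open. So does whether 4-acetamidophenyl would match 3-acetamidophenyl.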